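A few compounds are considered here, and "the series" means these few. Any claim that something is new, unique, unknown or untested is made for them only; others in the source may bear on it.

Series notes, benzylsulfanyl variation.

Going by the values given here, compound 2 `Cc1ccc(CSc2cc(Cl)c(C)cc2S(=O)(=O)/N=C(\N)n2nc(C)cc2-c2ccccc2)cc1` is the weaker of the two compounds measured so far: in a functional assay on HeLa cells (Homo sapiens) for cytotoxicity, read by MTT assay, with a stated time of 72 h (on this read-out lower numbers stand for stronger inhibition and higher numbers for weaker inhibition), compound 2 gives 62000 nM, the highest number in the set, while compound 1 `Cc1cc(-c2ccccc2)n(/C(N)=N/S(=O)(=O)c2cc(C)c(Cl)cc2SCc2cccc3ccccc23)n1` gives 3000 nM in this assay. Among the compounds with values here, the only step on record at this position, a 21-fold higher number from compound 1 to compound 2 (1.32 log units; beyond the scatter), shows that the group on the saturated chain carbon bound to a sulfur can move this assay a great deal.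

Compound 3 `Cc1cc(-c2ccccc2)n(/C(N)=N/S(=O)(=O)c2cc(C)c(Cl)cc2SCc2cccc(C(F)(F)F)c2)n1` keeps the shared core of compound 2 and differs in one place: 3-(trifluoromethyl)phenyl in place of 4-methylphenyl on a saturated chain carbon bound to a sulfur. Within the data shown here, no measured pair covers a trifluoromethyl-bearing ring here, so the step from compound 1 to compound 2 is the only guide, and it tells the direction of neither gain nor loss for this particular exchange, only that the range available is wide. Taking compound 2 as the anchor and allowing a shift in either direction, the estimate for compound 3 in this assay is 25000 nM, within 5000 nM to 90000 nM, which would be a step of a 2.5-fold lower number from compound 2 to compound 3 (0.39 log units; beyond the scatter) expected from compound 2 to compound 3.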

Compound 3, half-maximal inhibitory concentration: 98000 nM
Estimate against measurement, compound 3: 3.9-fold (0.59 log units) below, and the stated range ends below it.
By their numbers in this assay, from the lowest: compound 1; then compounds 2 and 3 (each within the scatter of the next).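

In this assay, 3-(trifluoromethyl)phenyl in place of 4-methylphenyl on a saturated chain carbon bound to a sulfur gives a difference within the scatter (a 1.6-fold higher number from compound 2 to compound 3 (0.20 log units; within the scatter)), so compound 2 and compound 3 cannot be told apart, even though the two groups differ in their substituent and in heavy atoms. The exchange of naphthalen-1-yl for 3-(trifluoromethyl)phenyl is a large step (a 33-fold higher number from compound 1 to compound 3 (1.51 log units; beyond the scatter)), and as both phenyl-bearing compounds now lie far from compound 1, the earlier large step no longer stands alone and compound 1 is the strongest of the three, with neither of the other two going against this. Nothing at hand gives a reason for this spread of numbers.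

The compounds shown leave open whether the low number of compound 1 is particular to naphthalen-1-yl or would also appear with naphthalen-2-yl, and they do not separate the identity of the phenyl substituent from its placement. As far as these compounds go, it also remains open how a phenyl ring carrying an amine or a carboxylic acid, or a longer chain between the sulfur and the ring, would read at this position.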